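The compounds below may be only part of what the source reports. "The series", "measured", "known", "first", "only" and "open" are said of these compounds alone.

Notes on the series. Among the measured compounds shown here, the shared core carries a basic ring nitrogen whose substituent varies, and this is the only place of change. In a functional assay on the whole organism for antagonist activity, with Mus musculus as the target (a higher number here means that more compound is needed for the effect, a lower number that less compound is needed), compound 1 `CCCCCCCN1CCC(C(=O)Nc2cc(Cl)c(N)cc2OC)CC1` gives only a limit, > 10 mg/kg. Compound 2 `COc1cc(N)c(Cl)cc1NC(=O)C1CCN(CC2CCCCC2)CC1` gives 2.9 mg/kg in this assay. Compound 3 `COc1cc(N)c(Cl)cc1NC(=O)C1CCN(C/C=C/c2ccccc2)CC1` likewise reaches only a limit in this assay, > 10 mg/kg. Compound 3 therefore stands at the edge of what the assay reports, sharing that position with compound 1 (the limit of > 10 mg/kg in this assay, at which 2 of the 3 values shown sit), while compound 2 alone gives a number. The step of an at least 3.4-fold lower number from compound 1 to compound 2 (0.53 log units; beyond the scatter) and the step of an at least 3.4-fold higher number from compound 2 to compound 3 (0.53 log units; beyond the scatter) both lie beyond the scatter, whereas the step that the two limits leave unreadable from compound 1 to compound 3 cannot be read.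

Compound 4 `COc1cc(N)c(Cl)cc1NC(=O)C1CCN(Cc2cccc(Cl)c2)CC1` is not yet measured. It differs from compound 3 by 3-chlorophenyl in place of 2-phenylethenyl on a saturated chain carbon bound to an amine nitrogen in a ring. The step that bears on this most is an at least 3.4-fold higher number from compound 2 to compound 3 (0.53 log units; beyond the scatter), where a cyclohexyl on the chain carbon gave a number and the 2-phenylethenyl group lost it; the change to 3-chlorophenyl again places a ring directly on that carbon. A lower number than the limit of compound 3 is therefore expected, its size uncertain, with a real chance that only a limit is reported again. Compound 4 is expected to give in this assay about 5 mg/kg, between 1.5 mg/kg and 20 mg/kg. The expected step is an at least 2.0-fold lower number from compound 3 to compound 4 (0.30 log units; that floor lies within the scatter).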

Compound 4, dose for half-maximal effect: > 4 mg/kg
Compound 4 ended at the assay's limit; the forecaster's own chance of this, stated with the estimate: 40%; the middle value is on the limit's open side.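

Compound 4 adds a third substituent that gives no number in this assay, and its limit is one that no other compound shown shares: the limit of > 4 mg/kg in this assay, at which 1 of the 4 values shown sits. The comparison with the cyclohexyl of compound 2 gives an at least 1.3-fold higher number from compound 2 to compound 4 (0.13 log units; that floor lies within the scatter), so this result shows no real loss from cyclohexyl to 3-chlorophenyl on the saturated chain carbon, though it does not show that the two groups match either. The steps from compound 1 and compound 3 to compound 4 cannot be read, which leaves hexyl, 2-phenylethenyl and 3-chlorophenyl unranked against one another, and cyclohexyl remains the only substituent here with an actual number.

From the compounds shown here alone, it stays open whether compound 4 lies close to compound 2 or far from it, since its limit is compatible with both. A plain phenyl or a cyclopentyl on the same chain carbon would help to separate the contribution of the aromatic ring from that of the chlorine and of ring size, a question that the compounds shown cannot settle.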